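Acetylation of a Secondary Hydroxyl in a Polyketide Series

This account rests on a few compounds, and the source may have more. Where it says the series, first, only, none or still open, it means among the compounds named here.

The study concerns a functional assay on U-373MG ATCC cells (Homo sapiens) for inhibition, read by MTT assay, with a stated time of 72 h; on this read-out higher numbers stand for weaker inhibition and lower numbers for stronger inhibition. Of the compounds shown here, two have been measured. Within the data shown here, compound 1, `CCc1oc([C@H](C)/C=C(\C)[C@H](OC(C)=O)[C@H](C)[C@@H](OC(=O)CC(C)C)[C@@H](C)c2oc([C@@H](C)[C@@H](O)CC)c(C)c(=O)c2C)c(C)c(=O)c1C`, is the only compound of the pair with a numerical result: in this assay compound 1 gives 21000 nM. Compound 2, `CCC(=O)[C@@H](C)c1oc([C@H](C)[C@@H]2O[C@](O)([C@@H](C)c3oc(CC)c(C)c(=O)c3C)[C@@H](C)[C@@H](O)[C@@H]2C)c(C)c(=O)c1C`, gives > 100000 nM in this assay, which is a limit of the assay rather than a number (the limit of > 100000 nM in this assay, at which 1 of the 2 values shown sits). Among the measured compounds shown here, no pair of measured compounds differs in a single place, so no measured step is available to guide expectations.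

The compound not yet measured is compound 3, `CCc1oc([C@H](C)/C=C(\C)[C@H](OC(C)=O)[C@H](C)[C@@H](OC(=O)CC(C)C)[C@@H](C)c2oc([C@@H](C)[C@H](CC)OC(C)=O)c(C)c(=O)c2C)c(C)c(=O)c1C`. It differs from compound 1 by acetyl in place of hydrogen on an oxygen on a saturated carbon. For the measured compounds named here, the change is small, a free hydroxy on a saturated chain carbon becoming an acetoxy, and nothing among the measured compounds shows what such a change does in this assay.

Compound 3 is therefore expected to sit close to compound 1, with the step of a 1.2-fold higher number from compound 1 to compound 3 (0.08 log units; within the scatter) expected to lie within the usual scatter or only slightly beyond it. The estimate for compound 3 in this assay is 25000 nM, within a range of 8000 nM to 80000 nM.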

Compound 3, half-maximal inhibitory concentration: 32000 nM
For compound 3 the middle estimate is 1.3-fold (0.11 log units) below the measured one, and the stated range covers the measured number.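

In this assay, among these compounds, the one step now available, a 1.5-fold higher number from compound 1 to compound 3 (0.18 log units; within the scatter), shows that acetyl in place of hydrogen on this oxygen on a saturated carbon leaves the read-out within the usual scatter, so compound 1 and compound 3 cannot be told apart here. Until this result, nothing shown had tested this position, and it now appears that the free hydroxy of the 2-hydroxy-1-methylbutyl group can be replaced by the acetoxy of the 2-acetoxy-1-methylbutyl group without a measurable difference in this assay. No measurement shown offers an explanation for this outcome, and the single step describes only this one change at this one position.

Going by these compounds, whether the position would accept other groups remains open: an amine, a carboxylic acid or a longer chain on this saturated carbon might give a result unlike that of the acetoxy, and a single step cannot show how far the tolerance seen here extends. It is also open whether the same exchange would have a similar outcome at the other oxygen-bearing carbons of the shared core, where the compounds shown offer no matching comparison.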